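A few compounds are considered here, and "the series" means these few. Any claim that something is new, unique, unknown or untested is made for them only; others in the source may bear on it.

Working notes on the series. In a functional assay on CHO cells with adenosine receptor A1 (Homo sapiens) as the target, read by cAMP accumulation and immunoassay, with a stated time of 6 min, tested at 1 uM (on this read-out higher numbers stand for a weaker effect at the one concentration tested and lower numbers for a stronger effect), compound 1 `Nc1scc(CN2CCN(c3ccc(Cl)cc3Cl)CC2)c1C(=O)c1ccc(Cl)cc1` gives -54%, compound 2 `Nc1scc(CN2CCN(c3ccc(F)cc3Cl)CC2)c1C(=O)c1ccc(Cl)cc1` gives -39% and compound 3 `COc1ccc(N2CCN(Cc3csc(N)c3C(=O)c3ccc(Cl)cc3)CC2)cc1` gives -15%. Compound 2 therefore holds the second highest of the three numbers; the nearest is compound 1, the furthest compound 3. All three measured changes sit on the aryl group carried by the ring nitrogen: a number 15 percentage points higher from compound 1 to compound 2 (beyond the scatter), a number 39 percentage points higher from compound 1 to compound 3 (beyond the scatter) and a number 24 percentage points higher from compound 2 to compound 3 (beyond the scatter). Compound 4 `Nc1scc(CN2CCN(c3ccc(Cl)c(C(F)(F)F)c3)CC2)c1C(=O)c1ccc(Cl)cc1` has not yet been measured in this assay. It differs from compound 2 only at that same position: 4-chloro-3-(trifluoromethyl)phenyl in place of 2-chloro-4-fluorophenyl on an amine nitrogen in a ring. Both steps that bear on it, from compound 1 to compound 2 and from compound 2 to compound 3, moved the number upward, but neither involved a 4-chloro-3-(trifluoromethyl)phenyl group, so direction here rests on the spread of the three measured aryl variants rather than on a direct precedent. For compound 4 a number near compound 2 is expected, the step of a number 6 percentage points lower from compound 2 to compound 4 (within the scatter) lying within the scatter. The estimate for compound 4 is -45%, with a range from -68% to -22%.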

Compound 4, a percentage reported as activity, at one concentration (the size of the read-out at that concentration, not a potency): -47%
For compound 4 the middle estimate is 2 percentage points above the measured one; measured number inside the range.
By their numbers in this assay, from the lowest: compounds 1, 4 and 2 (each within the scatter of the next, the first and the last beyond it); then compound 3.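

In this assay the 4-chloro-3-(trifluoromethyl)phenyl group on the amine nitrogen in the ring gives a number 8 percentage points lower from compound 2 to compound 4 (within the scatter) and a number 7 percentage points higher from compound 1 to compound 4 (within the scatter) so compound 4 cannot be told apart from either compound 1 or compound 2 on this read-out. The entering group holds more heavy atoms than 2-chloro-4-fluorophenyl, yet that change in count brings no step beyond the scatter, while a number 32 percentage points lower from compound 3 to compound 4 (beyond the scatter) keeps all three halogen-bearing aryl compounds clear of the 4-methoxyphenyl compound. Nothing measured on these compounds gives a reason for these steps.

On these data alone, whether a nitrile or a carboxylic acid on this aryl group would give numbers nearer compound 3 or nearer the halogen-bearing compounds stays open. So does the share of trifluoromethyl in this result, since it appears only together with chloro.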